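From bromo to methylsulfonyl on a shared core

The source may report more compounds than this note shows. Statements on the series, on what has been measured and on what is new or still open speak of the compounds shown alone.

compound 1 `O=C(O)c1cccc(C2=C(c3cc(Br)ccc3OCc3ccc(F)cc3)CCC2)c1` — < 3170 nM
compound 2 `O=C(O)c1cccc(C2=C(c3cc(Br)ccc3OCc3ccc(Cl)cc3)CCC2)c1` — < 3170 nM
compound 3 `O=C(O)c1cccc(C2=C(c3cc(Br)ccc3OCc3ccc(F)cc3F)CCC2)c1` — < 3170 nM

These three compounds were tested in an assay on isolated protein for inhibition of prostaglandin E2 receptor EP3 subtype (Homo sapiens); on this read-out lower numbers stand for stronger inhibition and higher numbers for weaker inhibition. For compound 1 the value given is a limit of the assay and not a number. For compound 2 the value is likewise a limit. For compound 3 the value is also a limit. Where compound 1 stands against the other two therefore cannot be read, since (the limit of < 3170 nM in this assay, at which 3 of the 3 values shown sit). The steps between the measured compounds are accordingly unreadable: a step that the two limits leave unreadable from compound 1 to compound 2, a step that the two limits leave unreadable from compound 1 to compound 3 and a step that the two limits leave unreadable from compound 2 to compound 3.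

Compound 4 `CS(=O)(=O)c1ccc(OCc2ccc(F)cc2)c(C2=C(c3cccc(C(=O)O)c3)CCC2)c1` has not yet been measured. It differs from compound 1 in one place: methylsulfonyl in place of bromo on an aromatic carbon. For the measured compounds named here, none of the measured steps involves the position that changes here, and each of them is unreadable, so they give no size of step to expect in this assay, in either direction, beyond the scatter. On this basis compound 4 is expected to give about 800 nM, with a range from 50 nM to 5000 nM. The step this expectation implies is a step that the limit leaves unreadable from compound 1 to compound 4, and it is expected that the result may again come back only as a limit.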

Compound 4, half-maximal inhibitory concentration: < 3170 nM
Compound 4 gave a limit, no number (the forecaster's own chance of this, stated with the estimate: 50%); the middle value lies beyond the limit too.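

In this assay, compound 4, like compound 1, gave only a limit and not a number, so the step between them cannot be read, and the same holds for all steps involving compound 2 and compound 3: the limit of < 3170 nM in this assay, at which 4 of the 4 values shown sit.

The compounds shown leave open whether methylsulfonyl in place of bromo changes the inhibition at all, and if so, in which direction and by how much.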